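This account rests on a few compounds, and the source may have more. Where it says the series, first, only, none or still open, it means among the compounds named here.

Among the measured compounds shown here, compound 3 `CS(=O)(=O)Nc1ccc(CNC(=O)c2ccc(N3CCC3)cc2)c(Cl)c1` gives 13000 nM in an assay on HeLa cells for agonist activity at Bile acid receptor (Homo sapiens), read by a luciferase reporter, with a stated time of 24 h (on this read-out higher numbers stand for an effect only at larger amounts of compound and lower numbers for an effect already at smaller amounts), the highest of the three numbers measured so far. Compound 1 `CCS(=O)(=O)Nc1ccc(CNC(=O)c2ccc(C(C)(C)C)cc2)c(Cl)c1` gives 500 nM in this assay, and compound 2 `CC(C)S(=O)(=O)Nc1ccc(CNC(=O)c2ccc(C(C)(C)C)cc2)c(Cl)c1` gives 420 nM. Compound 4 `CS(=O)(=O)Nc1ccc(CNC(=O)c2ccc(C(F)(F)C(F)(F)F)cc2)c(Cl)c1` is not yet measured. It differs from compound 3 in one place: 1,1,2,2,2-pentafluoroethyl in place of azetidin-1-yl on an aromatic carbon. For the measured compounds named here, no measured step touches this position. Going by the values given here, the only measured step, a 1.2-fold lower number from compound 1 to compound 2 (0.08 log units; within the scatter), concerns the sulfonamide side of the shared core and lies within the scatter, so it offers no guide to the size of the change here. Compounds 1 and 2 carry a different group at the same position and show far lower numbers than compound 3, yet they also differ from compound 3 on the sulfonamide side, so their gap to compound 3 cannot be assigned to one place alone. Compound 4 is therefore expected, with wide uncertainty, to move toward the numbers of compounds 1 and 2, a step of a 14-fold lower number from compound 3 to compound 4 (1.16 log units; beyond the scatter). In this assay, compound 4 is estimated at 900 nM, within a range from 200 nM to 5000 nM.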

Compound 4, half-maximal effective concentration: 3220 nM
Estimate against measurement, compound 4: 3.6-fold (0.55 log units) below; low and high end bracket the measured number.
By their numbers in this assay, from the lowest: compounds 2 and 1 (each within the scatter of the next); then compound 4; then compound 3.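

Among the compounds shown here, exchanging azetidin-1-yl for 1,1,2,2,2-pentafluoroethyl on this aromatic carbon gives a 4.0-fold lower number from compound 3 to compound 4 (0.61 log units; beyond the scatter) in this assay and is the first measured step at this position, showing that the group here affects the read-out while the rest of the structure stays the same. For this pair, an open chain without a ring or a hydrogen-bond acceptor gives the lower number, so neither the four-membered ring nor its acceptor is needed for activity in this series. No measurement here explains the change, and the swap alters several features at once, so the step cannot be assigned to any one of them.

On these data alone, how trifluoromethyl or an amine such as pyrrolidin-1-yl would compare at this place remains open. Also open, as far as these compounds go, is what tert-butyl would give on the unchanged core of compound 3.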